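A few compounds are considered here, and "the series" means these few. Any claim that something is new, unique, unknown or untested is made for them only; others in the source may bear on it.

Measured so far in a functional assay on MCF7 cells (Homo sapiens) for antiproliferative activity, read by MTT assay, with a stated time of 48 h; on this read-out higher numbers stand for weaker inhibition and lower numbers for stronger inhibition:
- compound 1 `Fc1ccc2[nH]c(-c3cn(-c4ccccc4)nc3-c3ccccc3)nc2c1` gives 2430 nM
- compound 2 `COc1ccc2[nH]c(-c3cn(-c4ccccc4)nc3-c3ccccc3)nc2c1` gives 1590 nM
- compound 3 `Fc1ccc(-c2nn(-c3ccccc3)cc2-c2nc3cc(F)ccc3[nH]2)cc1` gives 950 nM

Compound 3 stands clear of the first entry, with a 2.6-fold lower number from compound 1 to compound 3 (0.41 log units; beyond the scatter) as the gap. Compound 3 at 950 nM and compound 2 at 1590 nM lie within the scatter of each other.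

The next entry is compound 4 `O=C(OCc1ccccc1)c1ccc2[nH]c(-c3cn(-c4ccccc4)nc3-c3ccc(F)cc3)nc2c1`, and its change from the previous compound is benzyloxycarbonyl in place of fluoro on an aromatic carbon. In words, this is benzyloxycarbonyl in place of fluoro on an aromatic carbon, part of a fused or bridged system of two rings. The fluoro gained in a 2.6-fold lower number from compound 1 to compound 3 (0.41 log units; beyond the scatter) is kept in compound 4.

Within the data shown here, the only measured change at the carbon in question is a 1.5-fold lower number from compound 1 to compound 2 (0.18 log units; within the scatter), methoxy in place of fluoro, and it stays within the scatter. Among the measured compounds shown here, that step involves a much smaller group, so it sets no size for this one, and no measured compound carries benzyloxycarbonyl. The data therefore support no direction, and no shift beyond the scatter is expected, though with wide uncertainty.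

The expected change is a 1.3-fold higher number from compound 3 to compound 4 (0.10 log units; within the scatter), held loosely.

Compound 4 is estimated at 1200 nM, with an expected range from 350 nM to 4000 nM.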

Compound 4, half-maximal inhibitory concentration: 9240 nM
For compound 4 the middle estimate is 7.7-fold (0.89 log units) below the measured one; measured number above the stated range.
By their numbers in this assay, from the lowest: compounds 3, 2 and 1 (each within the scatter of the next, the first and the last beyond it); then compound 4.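

In this assay this carbon of the fused system of two rings now shows a clear response to its substituent: benzyloxycarbonyl in place of fluoro gives a 9.7-fold higher number from compound 3 to compound 4 (0.99 log units; beyond the scatter) and so weaker inhibition. Among these compounds, the only earlier change at this carbon, methoxy in place of fluoro, gave a 1.5-fold lower number from compound 1 to compound 2 (0.18 log units; within the scatter) and stayed within the scatter, so the earlier compounds showed no sensitivity here. The new group brings 10 heavy atoms, one six-membered aromatic ring of carbon only and 2 hydrogen-bond acceptors where a single fluorine stood, but nothing at hand bears on why the number rises.

Which part of benzyloxycarbonyl goes with the step stays open, and a methyl ester, a carboxylic acid, a primary amide or a benzyloxy group at the same carbon would help separate the carbonyl from the benzyl part. Also open, going by these compounds, is whether a small amine or a hydrogen at this carbon, with the fluoro on the other aromatic ring kept as in compound 3, would leave the number where it is or move it.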